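Swapping a Chlorophenyl for a Pyrrole on a Thiosemicarbazone

The compounds below may be only part of what the source reports. "The series", "measured", "known", "first", "only" and "open" are said of these compounds alone.

Of the compounds shown here, two sharing one core have been measured in a functional assay on HT-29 cells (Homo sapiens) for inhibition, read by sulforhodamine B assay, with a stated time of 48 h; on this read-out lower numbers stand for stronger inhibition of growth and higher numbers for weaker inhibition of growth. Compound 1 `CC1=CC[C@H](C(C)(C)NC(=S)NN)CC1` carries a free hydrazide end and in this assay compound 1 gives 60100 nM. Compound 2 `CC1=CC[C@H](C(C)(C)NC(=S)N/N=C/c2ccc(Cl)cc2)CC1` extends that end into a hydrazone bearing a 4-chlorophenyl group, and in this assay compound 2 gives 13600 nM. Of the two numbers, compound 2 has the lower one, and its gap to compound 1 lies beyond the usual scatter of such measurements.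

Compound 3 `CC1=CC[C@H](C(C)(C)NC(=S)N/N=C/c2ccc[nH]2)CC1` keeps everything of compound 2 except the aromatic group on the hydrazone: 1H-pyrrol-2-yl in place of 4-chlorophenyl on a carbon with a double bond to nitrogen. For the measured compounds named here, no measured pair shows what this particular exchange does, so the expectation rests only on the two numbers above. Because compound 2 gives 13600 nM with a 4-chlorophenyl group, and the smaller heteroaromatic ring is an untested change, compound 3 is expected to land somewhat weaker than compound 2, by a step that may not exceed the scatter. The step from compound 2 to compound 3 is estimated as a 1.8-fold higher number from compound 2 to compound 3 (0.26 log units; within the scatter). For compound 3 the expected value in this assay is 25000 nM, within a range from 8000 nM to 80000 nM.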

Compound 3, concentration for 50% growth inhibition: 27500 nM
The estimate for compound 3 lay 1.1-fold (0.04 log units) below the measured number; measured number inside the range.
By their numbers in this assay, from the lowest: compound 2; then compound 3; then compound 1.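

In this assay, the aromatic group on the hydrazone carbon turns out to matter: 1H-pyrrol-2-yl in place of 4-chlorophenyl on a carbon with a double bond to nitrogen gives a 2.0-fold higher number from compound 2 to compound 3 (0.31 log units; beyond the scatter), a modest step that still lies beyond the usual scatter. The hydrazone with the pyrrole also stays ahead of the free hydrazide end, with a 2.2-fold lower number from compound 1 to compound 3 (0.34 log units; beyond the scatter), so the lower number seen on extending that end is not limited to the 4-chlorophenyl group but also appears with a five-membered aromatic ring. No measurement shown here explains why compound 2 gives a lower number than compound 3.

This exchange changes several things at once: the ring size, the loss of the chlorine and the arrival of a ring nitrogen carrying a hydrogen, so the step cannot be assigned to any one of them. A plain phenyl group would show what the chlorine contributes, while a 1-methylpyrrol-2-yl or a furan-2-yl group would show whether the hydrogen on the pyrrole nitrogen plays any part.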